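Bromine for Iodine: Toxicity Toward Mouse Macrophages

The source may hold more compounds than are shown below. What is called first, only, known or untested is meant among the compounds shown, and "the series" means these compounds.

Two halogen-bearing compounds on one core were tested in an ADME assay on cells (Peritoneal macrophage, Mus musculus, strain Swiss) for cytotoxicity, with a stated time of 24 h; on this read-out higher numbers stand for lower toxicity in this test and lower numbers for higher toxicity in this test. Compound 1 `CC(C)(C)C1=CC(=O)C(I)=CC1=O` gives 35900 nM in this assay, and compound 2 `CC(C)(C)C1=CC(=O)C(Br)=CC1=O` gives 42300 nM. The difference between them is bromo in place of iodo on a double-bonded ring carbon and the step is a 1.2-fold higher number from compound 1 to compound 2 (0.07 log units; within the scatter). Compound 3 `O=C1C=C(I)C(=O)C(Cl)=C1Cl` sits on a different core; how the two cores differ is not broken down here. In this assay compound 3 reaches only a limit, > 100000 nM, which is the limit of > 100000 nM in this assay, at which 1 of the 3 values shown sits. Compound 4 `O=C1C=C(Br)C(=O)C(Cl)=C1Cl` has not yet been measured in this assay. Its difference from compound 3 is bromo in place of iodo on a double-bonded ring carbon. This is the same kind of change as that between compound 1 and compound 2, but the surroundings differ: in compound 4 the changed ring carbon lies two ring bonds from the ring atom that bears a chloro group and three ring bonds from the ring atom that bears a chloro group, whereas in compound 2 it lies three ring bonds from the ring atom that bears a tert-butyl group. The expected step is a step that the limit leaves unreadable from compound 3 to compound 4, resting on the earlier step of a 1.2-fold higher number from compound 1 to compound 2 (0.07 log units; within the scatter). Since compound 3 is known only as a limit, compound 4 is also expected to come out at or near that limit. The estimated value for compound 4 is 120000 nM, within a range from 50000 nM to 300000 nM.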

Compound 4, concentration lethal to 50% of the cells: > 100000 nM
Compound 4: a limit, no number; the forecaster's own chance of this, stated with the estimate: 70%; the middle value does not contradict the limit.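

In this assay, compound 3 and compound 4 each give a limit rather than a number, so no size can be read for the step of bromo in place of iodo between them: the limit of > 100000 nM in this assay, at which 2 of the 4 values shown sit.

The compounds shown leave open how far either compound lies past that limit, and whether this swap changes toxicity on their core at all.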